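A Ring Swap on a Weakly Cytotoxic Scaffold

A few compounds are considered here, and "the series" means these few. Any claim that something is new, unique, unknown or untested is made for them only; others in the source may bear on it.

compound 1 `COc1ccc(-c2nc(-c3c[nH]c4ccccc34)co2)cc1OC`: 103000 nM
compound 2 `c1ccc2c(-c3coc(-c4ccncc4)n3)c[nH]c2c1`: 105000 nM

Of the compounds shown here, two have been measured in a functional assay on MDA-MB-231 cells (Homo sapiens) for cytotoxicity, read by MTT assay, with a stated time of 48 h; a higher number here means a weaker inhibitor, a lower number a stronger inhibitor. Compound 1 gives 103000 nM in this assay. Compound 2 gives 105000 nM in this assay. Both numbers sit at the weak end of what such a test usually reports, and they lie within the scatter of each other, so the measurements do not separate the two compounds. Compound 2 carries the numerically higher of the two values, but the gap to compound 1 is too small to mean anything.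

The next compound, compound 3 `c1ccc2c(-c3coc(C4CCNCC4)n3)c[nH]c2c1`, keeps the core of compound 2 and changes one group: piperidin-4-yl in place of pyridin-4-yl on an aromatic carbon. For the measured compounds named here, no measured pair shows what such a swap does on this core, so there is no direct guide. Given how close compound 1 and compound 2 already are, and with no comparable step on record, the step of a 1.1-fold lower number from compound 2 to compound 3 (0.02 log units; within the scatter) is expected to be small and without a clear direction, staying within the scatter. Compound 3 is therefore estimated at 100000 nM, with a plausible range from 30000 nM to 300000 nM.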

Compound 3, half-maximal inhibitory concentration: 528000 nM
Beside the measured number, compound 3's estimate is 5.3-fold (0.72 log units) below it; measured number outside the range, above it.
By their numbers in this assay, from the lowest: compounds 1 and 2 (each within the scatter of the next); then compound 3.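

In this assay, this place on the five-membered aromatic ring turns out to respond to the group it carries: piperidin-4-yl in place of pyridin-4-yl gives a 5.0-fold higher number from compound 2 to compound 3 (0.70 log units; beyond the scatter), so compound 3 is the weaker inhibitor of that pair. Compound 1 at 103000 nM and compound 2 at 105000 nM lie within the scatter of each other, so they gave no sign of a change at this place that could move the number beyond the scatter. The swap keeps the ring size and the heavy-atom count, yet it replaces an aromatic ring with a non-aromatic one and adds a hydrogen-bond donor, and no measurement on hand gives a reason for the step.

The two changes arrive together, so the compounds shown cannot tell which of them goes with the higher number. As far as these compounds go, a cyclohexyl ring or a 1-methylpiperidin-4-yl group at this place could help pull them apart, and it remains open whether any group here gives a number clearly lower than those of compound 1 and compound 2.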